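Swapping ethyl for 1H-pyrazol-4-yl on a carbonyl carbon

This account rests on a few compounds, and the source may have more. Where it says the series, first, only, none or still open, it means among the compounds named here.

Compound 1 `Cc1ccc(C2CC=NN2C(=O)C(C)(C)C)cc1` gives 0.0383 h
Compound 2 `CC(C)(C)C(=O)N1N=CCC1c1cocn1` gives > 1.5 h as a limit, not a number
Compound 3 `CCC(=O)N1CCC(C(=O)N2N=CCC2c2ccccc2)CC1` gives 1.07 h
Compound 4 `O=C(c1cn[nH]c1)N1CCC(C(=O)N2N=CCC2c2ccccc2)CC1` is not yet measured

In an ADME assay on microsomes (Rattus norvegicus) for metabolic stability (on this read-out higher numbers stand for a longer-lived compound and lower numbers for a shorter-lived compound), compound 3 gives 1.07 h and stands highest of the two plain numbers, while compound 1 gives 0.0383 h and lies below it by a gap well beyond the usual scatter. Compound 2 gives > 1.5 h and this is a limit of the assay rather than a number.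

Compound 4 differs from compound 3 in one place, with 1H-pyrazol-4-yl in place of ethyl on a carbonyl carbon and the rest of the structure unchanged. That turns propanoyl into (1H-pyrazol-4-yl)carbonyl. Among the measured compounds shown here, no measured pair of compounds shows this change or any other single change, so the expectation rests on compound 3 at 1.07 h alone. The expected step of a 1.1-fold higher number from compound 3 to compound 4 (0.05 log units; within the scatter) in this assay is small, with no move beyond the scatter. Compound 4 is expected at 1.2 h with 0.6 h to 2.4 h as its estimated range.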

Compound 4, half-life: > 2.75 h
Compound 4: no number, only a limit (the forecaster's own chance of this, stated with the estimate: 35%); at least 2.2-fold (0.36 log units) between middle value and limit.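

In this assay, putting 1H-pyrazol-4-yl in place of ethyl on this carbonyl carbon, whose other neighbour is an amide-type nitrogen in a ring, gives an at least 2.5-fold higher number from compound 3 to compound 4 (0.40 log units; beyond the scatter). Among the compounds shown here, this is the only direct comparison at this position, and it shows that a five-membered aromatic ring with a hydrogen-bond donor can stand here with no loss in half-life. Compound 4 gives > 2.75 h, which is a limit and not a number, so the full size of the step stays unknown because the reading ends there: the limit of > 2.75 h in this assay, at which 1 of the 4 values shown sits.

One pair cannot tell whether the gain comes from having a ring at all or from the ring nitrogens and their hydrogen. A phenyl group or a longer chain such as butyl at the same place would help separate these possibilities.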